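Iodo to trifluoromethyl in a cytotoxicity series

The source may report more compounds than this note shows. Statements on the series, on what has been measured and on what is new or still open speak of the compounds shown alone.

Compound 1 (`O=Cc1cn(Cc2cccc(C(F)(F)F)c2)c2ccccc12`) : 140 nM
Compound 2 (`OCc1cn(Cc2cccc(I)c2)c2ccccc12`) : 100 nM

In a functional assay on NCI-H460 cells (Homo sapiens) for cytotoxicity, read by sulforhodamine B assay, with a stated time of 3 days (on this read-out higher numbers stand for weaker inhibition and lower numbers for stronger inhibition), compound 2 gives 100 nM and compound 1 gives 140 nM so the two stand level, within the usual scatter of each other. Compound 3 (`OCc1cn(Cc2cccc(C(F)(F)F)c2)c2ccccc12`) has not yet been measured. It departs from compound 2 in one place, with trifluoromethyl in place of iodo on an aromatic carbon, meta to a large group (trifluoromethyl in place of iodo on an aromatic carbon). Going by the values given here, no two measured compounds differ in one place only, so the data hold no direct measure of this exchange. Among the compounds with values here, the only guide is the closeness of compound 2 at 100 nM and compound 1 at 140 nM and that gives no ground to expect a large move. In this assay the expected change is small, an estimated 1.2-fold higher number from compound 2 to compound 3 (0.08 log units; within the scatter) with no step beyond the scatter foreseen and no firm direction. For compound 3 the estimated value is 120 nM with an expected range from 50 nM to 300 nM as its bounds.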

Compound 3, half-maximal inhibitory concentration: 39 nM
Compound 3: middle estimate off by 3.1-fold (0.49 log units), on the high side; measured number outside the range, below it.
By their numbers in this assay, from the lowest: compound 3; then compounds 2 and 1 (each within the scatter of the next).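

In this assay, going by these compounds alone, the place on the aromatic carbon, meta to a large group, proves sensitive to what it carries: with hydroxymethyl held constant, trifluoromethyl in place of iodo gives a 2.6-fold lower number from compound 2 to compound 3 (0.41 log units; beyond the scatter) and so moves the number beyond the scatter, which the earlier compounds could not show. The second exchange shows that the other substituent counts as well: with trifluoromethyl held constant, hydroxymethyl in place of formyl on an aromatic carbon gives a 3.6-fold lower number from compound 1 to compound 3 (0.56 log units; beyond the scatter) and leaves compound 3 with the lowest number of the three, beyond the scatter of both neighbours. Nothing in the available data accounts for either step.

With only iodo and trifluoromethyl to compare at the first place, the compounds shown leave open whether chloro, methoxy or nitrile on the same aromatic carbon would give a number close to that of compound 3 or one closer to that of compound 2. They also leave open how an amine or a carboxylic acid in place of hydroxymethyl would fare on the same core.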